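The source may hold more compounds than are shown below. What is called first, only, known or untested is meant among the compounds shown, and "the series" means these compounds.

Working notes on the series.

Compound 1 `C/C(=C\c1cc(-c2ccccc2)cs1)C(N)=O` is the reference. In a functional assay on HeLa cells (Homo sapiens) for cytotoxicity, read by CCK-8 assay, with a stated time of 24 h (a lower number here means a stronger inhibitor, a higher number a weaker inhibitor), compound 1 gives 12700 nM. Compound 2 `C/C(=C\c1cc(-c2ccc(C)cc2)cs1)C(N)=O` carries a methyl on the six-membered ring. In this assay compound 2 gives only a limit, > 50000 nM. So compound 2 stands at the weak end of what has been measured, and its value is a limit rather than a number (the limit of > 50000 nM in this assay, at which 1 of the 2 values shown sits). Within the data shown here, the one step between measured compounds, an at least 3.9-fold higher number from compound 1 to compound 2 (0.59 log units; beyond the scatter), shows that adding the methyl cost potency by at least that much.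

Compound 3 `C/C(=C\c1cc(-c2ccc(F)cc2)cs1)C(N)=O` has not yet been measured. It differs from compound 2 by fluoro in place of methyl on an aromatic carbon. Among the measured compounds shown here, the only measured step bearing on this change is an at least 3.9-fold higher number from compound 1 to compound 2 (0.59 log units; beyond the scatter), where the methyl entered and the number rose at least modestly. Removing the methyl again, with a fluoro in its place, is expected to reverse part of that loss, so a downward step an at least 1.7-fold lower number from compound 2 to compound 3 (0.25 log units; that floor lies within the scatter) in this assay is expected, though compound 2 sits at a limit and the size is uncertain. Compound 3 is therefore estimated at 28000 nM, with a range from 10000 nM to 60000 nM.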

Compound 3, half-maximal inhibitory concentration: 20800 nM
Beside the measured number, compound 3's estimate is 1.3-fold (0.13 log units) above it, and the stated range covers the measured number.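

In this assay, fluoro in place of hydrogen on this aromatic carbon, para to a large group, gives a 1.6-fold higher number from compound 1 to compound 3 (0.21 log units; within the scatter), so compound 1 and compound 3 cannot be told apart here. Fluoro in place of methyl at the same carbon gives an at least 2.4-fold lower number from compound 2 to compound 3 (0.38 log units; beyond the scatter), which shows that the loss seen with the methyl does not extend to every group placed at this carbon. The size of that step remains a floor, since the value of compound 2 is a limit and not a number: the limit of > 50000 nM in this assay, at which 1 of the 3 values shown sits.

Only hydrogen, methyl and fluoro are shown at this carbon, so it stays open whether a chloro, methoxy or trifluoromethyl group there would give a number in line with compound 3 or with compound 2. From the compounds shown here alone, it also stays open whether any change elsewhere on the shared core, such as a carboxylic acid in place of the amide or a longer chain in place of the methyl on the alkene, would move the number beyond that of compound 1.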